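Removing a Methoxy Group: Expected Effect on Cell Activity

The compounds below may be only part of what the source reports. "The series", "measured", "known", "first", "only" and "open" are said of these compounds alone.

Measured so far:
compound 1 `Cc1c(C)c2c(c(C)c1OCc1ccccc1)CCC(C)(COc1ccc(/C=C3\SC(=O)NC3=O)cc1)O2` gives 85%
compound 2 `CC(C)=CCOc1c(C)c(C)c2c(c1C)CCC(C)(COc1ccc(/C=C3\SC(=O)NC3=O)cc1F)O2` gives 95%
compound 3 `COc1cc(/C=C2\SC(=O)NC2=O)ccc1OCC1(C)CCc2c(C)c(OCC=C(C)C)c(C)c(C)c2O1` gives 95%

In a functional assay on MCF7 cells (Homo sapiens), tested at 2.5 uM (a higher number here means a weaker effect of the compound at the concentration tested, a lower number a stronger effect), compound 3 stands level with compound 2 at the digits shown, the two together the highest of the three numbers, while compound 1 sits lower but within the scatter. Within the data shown here, the only measured single-point step, no change at the digits printed from compound 2 to compound 3 (within the scatter), exchanged one aromatic substituent for another and showed no change beyond the scatter.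

Compound 4 `CC(C)=CCOc1c(C)c(C)c2c(c1C)CCC(C)(COc1ccc(/C=C3\SC(=O)NC3=O)cc1)O2` differs from compound 3 by hydrogen in place of methoxy on an aromatic carbon. That step touches the same aromatic carbon as the measured step, which was flat, so the change expected here, a number 2 percentage points lower from compound 3 to compound 4 (within the scatter), is none beyond the scatter. Compound 4 is therefore estimated at 93%, with a range from 80% to 102%.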

Compound 4, a percentage reported as activity, at one concentration (the size of the read-out at that concentration, not a potency): 76%
Beside the measured number, compound 4's estimate is 17 percentage points above it, outside the stated range (below it).
By their numbers in this assay, from the lowest: compounds 4, 1, 2 and 3 (each within the scatter of the next, the first and the last beyond it).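

In this assay the aromatic carbon that stayed flat when methoxy and fluoro were exchanged responds once it carries hydrogen: removing methoxy gives a number 19 percentage points lower from compound 3 to compound 4 (beyond the scatter) and hydrogen in place of fluoro gives a number 19 percentage points lower from compound 2 to compound 4 (beyond the scatter) by the same amount. Both substituents therefore part from hydrogen here, though not from each other. The other single change gives a number 9 percentage points lower from compound 1 to compound 4 (within the scatter) with 2-methylprop-1-en-1-yl in place of phenyl on a saturated chain carbon bound to an oxygen on an aromatic ring. Nothing available explains the effect of hydrogen at this position. On these data alone, whether an amine or a hydroxyl group on this carbon would behave like hydrogen or like methoxy stays open.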